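Swapping 3-methoxyphenyl for cyclohexyl on the amide

The source may hold more compounds than are shown below. What is called first, only, known or untested is meant among the compounds shown, and "the series" means these compounds.

In an ADME assay on Huh-7 cells (Homo sapiens) for cytotoxicity, with a stated time of 3 days (on this read-out lower numbers stand for higher toxicity in this test and higher numbers for lower toxicity in this test), compound 1 `COc1cccc(NC(=O)c2c(NO)cc(-c3ccccc3)oc2=O)c1` gives > 20000 nM, which is a limit of the assay and not a number. Compound 2 `O=C(Nc1ccccc1O)c1c(NO)cc(-c2ccccc2)oc1=O`, with 2-hydroxyphenyl on the same amide-type nitrogen, gives 14000 nM. For the measured compounds named here, that is the only measured change at this nitrogen, a step of an at least 1.4-fold lower number from compound 1 to compound 2 (0.15 log units; that floor lies within the scatter). Compound 3 `O=C(NC1CCCCC1)c1c(NO)cc(-c2ccccc2)oc1=O` carries cyclohexyl in place of 3-methoxyphenyl on that nitrogen (cyclohexyl in place of 3-methoxyphenyl on an amide-type nitrogen). Going by the values given here, with only that small step to go on, no change beyond the scatter is expected, and the estimated step is an at least 1.1-fold lower number from compound 1 to compound 3 (0.04 log units; that floor lies within the scatter). Compound 3 is expected at about 18000 nM. The expected range for compound 3 runs from 8000 nM to 40000 nM.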

Compound 3, half-maximal cytotoxic concentration: 10500 nM
The estimate for compound 3 lay 1.7-fold (0.23 log units) above the measured number; the measured number falls inside the stated range.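

In this assay, a ring that is not aromatic now sits on the amide-type nitrogen, and the step is a 1.3-fold lower number from compound 2 to compound 3 (0.12 log units; within the scatter), so cyclohexyl and 2-hydroxyphenyl cannot be told apart here. Against 3-methoxyphenyl, the step is an at least 1.9-fold lower number from compound 1 to compound 3 (0.27 log units; that floor lies within the scatter). Compound 1 gives only a limit of the assay, so that step is a floor and not a measured size: the limit of > 20000 nM in this assay, at which 1 of the 3 values shown sits.

Going by these compounds, whether a longer chain, an amine or a carboxylic acid on this nitrogen would shift the number beyond the scatter stays open. On these data alone, the true distance between compound 1 and compound 3 also stays open.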